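The source may report more compounds than this note shows. Statements on the series, on what has been measured and on what is new or still open speak of the compounds shown alone.

Measured in an ADME assay on microsomes from liver (Mus musculus, strain CD-1) for metabolic stability, read by LC-MS, tested at 2 uM; a higher number here means that the compound lasts longer, a lower number that the compound disappears faster:

Compound 1 `Cn1ccc2ccc(-c3cc(Nc4ccccc4S(=O)(=O)Nc4cncnc4)cc4nccnc34)cc21`: 0.683 h
Compound 2 `Cn1cc(NC(=O)c2ccncc2Nc2cc(-c3ccc4ccn(C)c4c3)c3nccnc3c2)cn1`: 0.2 h

Of these two, compound 2 stands lowest at 0.2 h. Compound 1 gives 0.683 h, and that gap is beyond the usual scatter. The two compounds differ in more than one place, however, so their gap cannot be tied to any single change.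

Compound 3 `Cn1ccc2ccc(-c3cc(Nc4cnccc4C(=O)NCC4COCCN4)cc4nccnc34)cc21` follows from compound 2 through one change, with (morpholin-3-yl)methyl in place of 1-methyl-1H-pyrazol-4-yl on an amide-type nitrogen.

For the measured compounds named here, no step between measured compounds shows what such a replacement does in this assay, so the expectation remains loose. The higher number of compound 1, at 0.683 h, leans it slightly upward. The estimated change is a 1.5-fold higher number from compound 2 to compound 3 (0.18 log units; within the scatter), a small rise that is not expected to go beyond the scatter. Compound 3 is expected at 0.3 h, with an estimated range of 0.12 h to 0.7 h.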

Compound 3, half-life: > 1 h
Compound 3: only a limit was reported (the forecaster's own chance of this, stated with the estimate: 5%); middle value at least 3.3-fold (0.52 log units) away from the limit.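

In this assay compound 3 gives > 1 h, which is a limit of the assay and not a number. For the compounds shown here, this is the first step that can be read at this position: (morpholin-3-yl)methyl in place of 1-methyl-1H-pyrazol-4-yl on an amide-type nitrogen gives an at least 5.0-fold higher number from compound 2 to compound 3 (0.69 log units; beyond the scatter), so this one replacement, with the rest of the structure unchanged, moves the half-life beyond the scatter, and upward. The full size of that rise stays unknown because the reading for compound 3 ends at a limit: the limit of > 1 h in this assay, at which 1 of the 3 values shown sits.

The compounds shown leave open which part of the entering group goes with the rise, since the change swaps a five-membered aromatic ring for a six-membered non-aromatic ring and brings in a methylene link at the same time. As far as these compounds go, a piperidin-4-yl ring, a plain morpholin-4-yl ethyl chain or a simple hydroxyethyl chain on the same nitrogen could help separate these features, and whether the rise would carry over to a different core also remains open.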